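Sulfamoyl for ethoxycarbonyl in a cyanoaziridine urea series

The source may report more compounds than this note shows. Statements on the series, on what has been measured and on what is new or still open speak of the compounds shown alone.

Compound 1 `CCOC(=O)c1ccc(NC(=O)N2CC2C#N)cc1` and compound 2 `N#CC1CN1C(=O)NCc1ccccc1` were tested in a functional assay on MCF7 cells (Homo sapiens) for inhibition; on this read-out higher numbers stand for weaker inhibition and lower numbers for stronger inhibition. In this assay compound 1 gives 2100 nM, the lowest of the two numbers in hand. In this assay compound 2 gives 6000 nM, a higher number than that of compound 1, and the gap between the two lies beyond the usual scatter of repeated measurements. Compound 3 `N#CC1CN1C(=O)Nc1ccc(S(N)(=O)=O)cc1` has not yet been measured in this assay. It differs from compound 1 in one place: sulfamoyl in place of ethoxycarbonyl on an aromatic carbon. Going by the values given here, no measured pair in this set shows the effect of sulfamoyl in place of ethoxycarbonyl on an aromatic carbon, so the size of the step is not known from the data. The expected step of a 1.2-fold higher number from compound 1 to compound 3 (0.08 log units; within the scatter) is small, with no clear direction, and is not expected to go beyond the scatter. In this assay compound 3 is therefore expected to give about 2500 nM, with a plausible range from 800 nM to 8000 nM, close to the value of compound 1 at 2100 nM.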

Compound 3, half-maximal inhibitory concentration: > 15000 nM
Compound 3: no number, only a limit; the forecaster's own chance of this, stated with the estimate: 10%; middle value at least 6.0-fold (0.77 log units) away from the limit.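

Sulfamoyl in place of ethoxycarbonyl on an aromatic carbon gives an at least 7.1-fold higher number from compound 1 to compound 3 (0.85 log units; beyond the scatter) in this assay, the first evidence that the group at this position affects inhibition and that this change weakens it beyond the scatter. Sulfamoyl also brings a hydrogen-bond donor that ethoxycarbonyl lacks, but the data cannot say whether this or another difference between the two groups accounts for the step. Compound 3 gives > 15000 nM, which is a limit and not a number, so the step is known from one side only and its full size stays undetermined: the limit of > 15000 nM in this assay, at which 1 of the 3 values shown sits.

The compounds shown leave open how other groups on this aromatic carbon would read in this assay, among them a carboxylic acid, a carboxamide or a methylsulfonyl group. Methylsulfonyl would be especially informative, since it keeps the sulfur and both oxygens of sulfamoyl but replaces its nitrogen with a carbon, and so would test whether that nitrogen is tied to the step.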